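The source may hold more compounds than are shown below. What is called first, only, known or untested is meant among the compounds shown, and "the series" means these compounds.

Measured in a functional assay on L1210 (1565) cells (Mus musculus) for cytotoxicity (a lower number here means that less compound is needed, a higher number that more compound is needed for the effect), so far:
- compound 1 `CCOc1cc(-c2ccccc2)nc2ccccc12` gives > 10 ug/mL as a limit
- compound 2 `Oc1ccc2c(O)cc(-c3ccccc3)nc2c1` gives 0.45 ug/mL as a number
- compound 3 `CCCOc1cc(-c2ccccc2)nc2ccccc12` gives > 10 ug/mL as a limit

Compound 3 has no numerical value, only the limit of > 10 ug/mL in this series. For the measured compounds named here, compound 1 has the same limit, and the overall picture is the limit of > 10 ug/mL in this assay, at which 2 of the 3 values shown sit, with compound 2 supplying the only actual number.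

The next structure is compound 4 `CS(=O)(=O)Oc1cc(-c2ccccc2)nc2ccccc12` and the change from compound 3 is methylsulfonyl in place of propyl on an oxygen on an aromatic ring with methylsulfonyl in place of propyl on an oxygen on an aromatic ring.

Going by the values given here, the only measured step bearing on this place is a step that the two limits leave unreadable from compound 1 to compound 3 and it gives no size or direction to carry over. That step also involves a different kind of change. Among the compounds with values here, no size of step in this assay can therefore be argued from the data, and no direction is favoured.

The working expectation stays close to the limit held by compound 3 at > 10 ug/mL as the only reference point. The expected change is a step that the limit leaves unreadable from compound 3 to compound 4 with wide uncertainty on that estimate.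

Compound 4 is estimated at 12 ug/mL with an expected range of 4 ug/mL to 40 ug/mL and a report as a limit is the likelier outcome.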

Compound 4, half-maximal effective concentration: 6.04 ug/mL
Beside the measured number, compound 4's estimate is 2.0-fold (0.30 log units) above it; measured number inside the range.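

In this assay compound 4 gives 6.04 ug/mL as an actual number. A group on this oxygen on an aromatic ring can therefore bring the series off the limit that holds for the propoxy and ethoxy compounds. Methylsulfonyl in place of propyl gives an at least 1.6-fold lower number from compound 3 to compound 4 (0.21 log units; that floor lies within the scatter) at this place, and methylsulfonyl in place of ethyl gives an at least 1.6-fold lower number from compound 1 to compound 4 (0.21 log units; that floor lies within the scatter) at the same place. Both steps are floors that lie within the scatter, so they point towards a lower number for the (methylsulfonyl)oxy compound without establishing a difference from either ether, although the real gaps may be wider than these floors.

The true size of both steps stays unread, and the picture at this position still rests heavily on limits: the limit of > 10 ug/mL in this assay, at which 2 of the 4 values shown sit. Also open, as far as these compounds go, is how an amine or a carboxylic acid carried on this oxygen, or a sulfonyl group bearing a longer chain in place of methyl, would read in this assay against the value of compound 4.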